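One Aromatic Group Exchanged, Little Change Expected

The source may report more compounds than this note shows. Statements on the series, on what has been measured and on what is new or still open speak of the compounds shown alone.

In a functional assay on MCF7 cells (Homo sapiens) for antiproliferative activity, read by MTT assay, with stated times of 24 h and 72 h (a higher number here means a weaker inhibitor, a lower number a stronger inhibitor), compound 1 `COc1cc(N2C(=O)[C@@H](Oc3ccccc3)[C@H]2c2ccc(Br)cc2)cc(OC)c1OC` gives 48000 nM and compound 2 `CCOC(=O)/C=C/c1ccc([C@@H]2[C@H](Oc3ccccc3)C(=O)N2c2cc(OC)c(OC)c(OC)c2)cc1` gives 87000 nM. Among the compounds with values here, these two numbers lie within the scatter of each other, so compound 2 stands level with the only other measured compound. Compound 3 `COc1cc(N2C(=O)[C@@H](Oc3ccccc3)[C@H]2c2ccc([S+](C)[O-])cc2)cc(OC)c1OC` keeps the shared core and alters one group of compound 2: a group of 3 heavy atoms (1 carbon, 1 oxygen, 1 sulfur; no ring) in place of a group of 7 heavy atoms (5 carbon, 2 oxygen; no ring), on an aromatic carbon. This group sits para to a large group. Within the data shown here, the only measured step that bears on this change is the exchange of bromo for 2-(ethoxycarbonyl)ethenyl at the same place: a 1.8-fold higher number from compound 1 to compound 2 (0.26 log units; within the scatter). That single step is thin evidence, but it points to no expected change beyond the scatter in this assay. The estimate amounts to an expected 1.5-fold lower number from compound 2 to compound 3 (0.16 log units; within the scatter). For compound 3, the expected value is 60000 nM, with an estimated range from 20000 nM to 150000 nM.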

Compound 3, half-maximal inhibitory concentration: 20000 nM
The estimate for compound 3 lay 3.0-fold (0.48 log units) above the measured number; the range from low to high includes it.
By their numbers in this assay, from the lowest: compound 3; then compounds 1 and 2 (each within the scatter of the next).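

In this assay, this position on the aromatic ring turns out to respond to a change of group: the group of 3 heavy atoms that holds sulfur gives a 4.4-fold lower number from compound 2 to compound 3 (0.64 log units; beyond the scatter) when it replaces 2-(ethoxycarbonyl)ethenyl, and a 2.4-fold lower number from compound 1 to compound 3 (0.38 log units; beyond the scatter) when it replaces one bromine atom. Within the data shown here, the two earlier groups stayed within the scatter of each other, so this is the first change here to move the number beyond the scatter, and compound 3 is the strongest of the three. Nothing measured in this set says why this group stands apart from the other two.

On these data alone, it remains open whether the gain belongs to this sulfur-bearing group alone or would also appear with another group at this position, such as an amine or a carboxylic acid.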